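This account rests on a few compounds, and the source may have more. Where it says the series, first, only, none or still open, it means among the compounds named here.

Measured compounds:
- compound 1, `CNC(=O)c1cc(Oc2ccc(NC(=O)c3cc4cccnc4n(-c4ccc(Cl)cc4)c3=O)cc2)ccn1`: 390 nM
- compound 2, `CNC(=O)c1cc(Oc2ccc(NC(=O)c3cc4cccnc4n(-c4ccc(F)c(Cl)c4)c3=O)cc2)ccn1`: 1810 nM
- compound 3, `CCNC(=O)c1cc(Oc2ccc(NC(=O)c3cc4cccnc4n(-c4ccccc4F)c3=O)cc2)ccn1`: 260 nM

All numbers come from a functional assay on HT-29 cells (Homo sapiens) for antiproliferative activity, read by MTT assay, with a stated time of 72 h; a lower number here means a stronger inhibitor, a higher number a weaker inhibitor. Compound 3 has the lowest number of the three, but compound 1 sits within the scatter of it, so no order between those two can be claimed; compound 2 lies beyond the scatter from compound 3.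

Compound 4, `CCNC(=O)c1cc(Oc2ccc(NC(=O)c3cc4cccnc4n(-c4ccc(Br)cc4F)c3=O)cc2)ccn1`, differs from compound 3 by bromo in place of hydrogen on an aromatic carbon.

Within the data shown here, only one step is available: a 4.6-fold higher number from compound 1 to compound 2 (0.67 log units; beyond the scatter). It concerns the same aryl group on the aromatic nitrogen, but there a fluoro was added and a chloro moved, whereas here a bromo is added with the fluoro left in place. Among the measured compounds shown here, that step therefore bears on the change only loosely, and no step shows the effect of a bromo as such. Compound 1 carries a halogen at the position where compound 4 gains its bromo, and its number is within the scatter of compound 3.

Taken together, the step in this assay is expected to be small, most likely toward a somewhat higher number, a 1.6-fold higher number from compound 3 to compound 4 (0.21 log units; within the scatter), and the estimate carries a wide range. Compound 4 is expected to give 420 nM, between 150 nM and 1200 nM.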

Compound 4, half-maximal inhibitory concentration: 2070 nM
Estimate against measurement, compound 4: 4.9-fold (0.69 log units) below; the measured number lies above the stated range.
By their numbers in this assay, from the lowest: compounds 3 and 1 (each within the scatter of the next); then compounds 2 and 4 (each within the scatter of the next).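

In this assay, among these compounds, bromo in place of hydrogen on the aromatic carbon para to a large group and meta to a fluoro group gives an 8.0-fold higher number from compound 3 to compound 4 (0.90 log units; beyond the scatter), the first reading of a single change at this carbon. The 2-fluorophenyl to 4-bromo-2-fluorophenyl change is therefore not neutral in this read-out, and the added halogen goes with a weaker result on this shared core. The only other listed change on the aryl group on the aromatic nitrogen, a 4.6-fold higher number from compound 1 to compound 2 (0.67 log units; beyond the scatter), also runs toward a higher number, but it alters a different substitution pattern and gives no direct reading of bromo at this carbon. The data give no measured basis for explaining the size of the step from compound 3 to compound 4.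

Still open, on these data alone, is whether the higher number belongs to bromo specifically or extends to other groups at this carbon, such as a methyl, a methoxy or an amine, each on the same 2-fluorophenyl group. Also open, as far as these compounds go, is whether bromo at this carbon gives a similar step when the fluoro group is absent or when the ethyl amide is replaced by the methyl amide.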